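Benzamido to acetamido: notes on the series

The source may report more compounds than this note shows. Statements on the series, on what has been measured and on what is new or still open speak of the compounds shown alone.

Measured so far in a functional assay on B16 cells (Mus musculus) for inhibition; a higher number here means a weaker inhibitor, a lower number a stronger inhibitor
Compound 1 `COc1cc(/C=C/C(=O)c2cccc(NC(=O)c3ccc(Cl)c(Cl)c3)c2)ccc1O` gives 3.88 ug/mL
Compound 2 `COc1cc(/C=C/C(=O)c2cccc(NC(=O)C(C)C)c2)ccc1O` gives 1.09 ug/mL
Compound 3 `COc1cc(/C=C/C(=O)c2cccc(NC(=O)c3ccccc3)c2)ccc1O` gives 0.82 ug/mL

Compound 3 stands at the low end of the three numbers together with compound 2, and the gap between them (a 1.3-fold lower number from compound 2 to compound 3 (0.12 log units; within the scatter)) lies within the scatter. Compound 1 stands apart from compound 3 (a 4.7-fold lower number from compound 1 to compound 3 (0.68 log units; beyond the scatter)).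

Next is compound 4 `COc1cc(/C=C/C(=O)c2cccc(NC(C)=O)c2)ccc1O`, which has methyl in place of phenyl on a carbonyl carbon, turning benzamido into acetamido (methyl in place of phenyl on a carbonyl carbon). Three measured steps change this same group. The step from compound 1 to compound 2 (a 3.6-fold lower number from compound 1 to compound 2 (0.55 log units; beyond the scatter)) and the step already given for compound 3 are modest, and both start from compound 1. The step closest to the present change replaces isopropyl with phenyl (a 1.3-fold lower number from compound 2 to compound 3 (0.12 log units; within the scatter)), and it shows no effect beyond the scatter. Among the measured compounds shown here, no measured compound carries methyl here, so this is an extrapolation. The expected step is therefore small, within the scatter and perhaps slightly upward (a 1.3-fold higher number from compound 3 to compound 4 (0.13 log units; within the scatter)). In this assay compound 4 is expected at an estimated value (1.1 ug/mL with a range from 0.55 ug/mL to 2.2 ug/mL).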

Compound 4, half-maximal inhibitory concentration: 3.62 ug/mL
Compound 4: the middle estimate sits 3.3-fold (0.52 log units) below what was measured, outside the stated range (above it).
By their numbers in this assay, from the lowest: compounds 3 and 2 (each within the scatter of the next); then compounds 4 and 1 (each within the scatter of the next).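

Methyl on this carbonyl carbon is not interchangeable with phenyl or isopropyl in this assay: a 4.4-fold higher number from compound 3 to compound 4 (0.64 log units; beyond the scatter) and a 3.3-fold higher number from compound 2 to compound 4 (0.52 log units; beyond the scatter) are both beyond the scatter, whereas the earlier exchange of isopropyl for phenyl showed no effect beyond it. The position is therefore sensitive to changes that do not involve the 3,4-dichlorophenyl group, which was the starting point of both earlier steps beyond the scatter. With a 1.1-fold lower number from compound 1 to compound 4 (0.03 log units; within the scatter) within the scatter, the four groups fall into two pairs, phenyl with isopropyl and methyl with 3,4-dichlorophenyl, so each pair holds one group with an aromatic ring and one without, and the presence of a ring alone does not sort the series.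

Ethyl and cyclopropyl on the same carbonyl carbon would test how the number moves among the ring-free groups, and a monochlorophenyl group would test whether one chlorine is enough to separate a ring-bearing group from phenyl. The data at hand give no measured basis for explaining why methyl and 3,4-dichlorophenyl sit together, apart from phenyl and isopropyl.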